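The source may report more compounds than this note shows. Statements on the series, on what has been measured and on what is new or still open speak of the compounds shown alone.

Measured so far in an assay on CHO-TREX cells for antagonist activity at transient receptor potential cation channel subfamily A member 1 (Homo sapiens), read by FLIPR and calcium flux, with a stated time of 10 min; a lower number here means a stronger inhibitor, a higher number a weaker inhibitor:
compound 1 `FC(F)(F)Oc1ccccc1-c1ccc2[nH]ncc2c1` gives 3430 nM
compound 2 `Fc1cc2[nH]ncc2cc1-c1ccccc1C(F)(F)F` gives 48 nM

Compound 2 holds the lower of the two numbers; compound 1 sits a long way higher, beyond the scatter, so compound 2 is the stronger inhibitor of the pair. The next step leads to compound 3 `CNC(=O)c1cc2[nH]ncc2cc1-c1ccccc1C(F)(F)F`, which differs from compound 2 in one place: methylcarbamoyl in place of fluoro on an aromatic carbon. Among the compounds with values here, no step between two measured compounds of this kind is available, so the expected effect of the change rests on the structural change alone, with the amide group entering on the shared core where only a single fluorine sat before. Compound 3 is expected to land near compound 2 or somewhat weaker, a modest step of a 2.5-fold higher number from compound 2 to compound 3 (0.40 log units; beyond the scatter) toward a higher number. The estimate for compound 3 in this assay is 120 nM, with a range from 25 nM to 600 nM.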

Compound 3, half-maximal inhibitory concentration: > 30000 nM
Compound 3: a limit, no number; the forecaster's own chance of this, stated with the estimate: 5%; at least 250-fold (2.39 log units) between middle value and limit.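

In this assay, fluoro is exchanged for methylcarbamoyl on this aromatic carbon of the shared core, and the result is an at least 620-fold higher number from compound 2 to compound 3 (2.79 log units; beyond the scatter), so inhibition is not kept with this group here. Compound 3 carries a limit of the assay, not a number: the limit of > 30000 nM in this assay, at which 1 of the 3 values shown sits.

Compound 1 and compound 2 differ in more than one place and gave no reading of this carbon, so this is the only step on it shown.

Open, from the compounds shown here alone, is which part of the entering group goes with the loss: the amide hydrogen, the carbonyl or the methyl cannot be separated with a single compound. A nitrile, a primary carboxamide, dimethylcarbamoyl or an amine on the same carbon would show whether any group other than fluoro keeps inhibition at this place.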